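A few compounds are considered here, and "the series" means these few. Any claim that something is new, unique, unknown or untested is made for them only; others in the source may bear on it.

Measured so far:
compound 1, `CCCCNc1nc(N)nc2c1CN(C(=O)c1ccccc1)CC2` — 1.4 uM
compound 2, `CCCCNc1nc(N)nc2c1CN(Cc1cccc(Cl)c1Cl)CC2` — 0.18 uM
compound 3, `CCCCNc1nc(N)nc2c1CN(Cc1c(Cl)cccc1Cl)CC2` — 0.14 uM

All three share one core and differ only in the group attached to the ring nitrogen. In an assay on HEK293 cells for agonist activity at Toll-like receptor 8 (Homo sapiens), read by a luciferase reporter, with a stated time of 6 h (a higher number here means that more compound is needed for the effect, a lower number that less compound is needed), compound 3 gives the lowest number of the three. Compound 2 sits right beside it, and the step of a 1.3-fold lower number from compound 2 to compound 3 (0.11 log units; within the scatter) shows that swapping 2,6-dichlorophenyl for 2,3-dichlorophenyl changes nothing that can be trusted. Compound 1, which carries a benzoyl group instead of a substituted benzyl group, gives a number well above both.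

Compound 4, `CCCCNc1nc(N)nc2c1CN(Cc1cccnc1)CC2`, has not yet been measured. Its difference from compound 3 is pyridin-3-yl in place of 2,6-dichlorophenyl on a saturated chain carbon bound to an amine nitrogen in a ring.

Going by the values given here, no measured step removes the two chlorine atoms or puts a nitrogen into the aromatic ring, so there is no direct guide. Among the compounds with values here, the one step that bears on the aromatic group, compound 2 to compound 3, is within the scatter and only tells that the arrangement of chlorines hardly matters. Compound 1 shows that the core itself still works with a plain phenyl ring, though its carbonyl link muddies the comparison. A modest rise in the number is therefore expected, as a 4.3-fold higher number from compound 3 to compound 4 (0.63 log units; beyond the scatter). Compound 4 is estimated at 0.6 uM, with a likely range from 0.2 uM to 2 uM.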

Compound 4, minimum effective concentration: 0.13 uM
Compound 4: middle estimate off by 4.6-fold (0.66 log units), on the high side; the whole stated range lies above it.
By their numbers in this assay, from the lowest: compounds 4, 3 and 2 (each within the scatter of the next); then compound 1.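

In this assay, the steps of a 1.1-fold lower number from compound 3 to compound 4 (0.03 log units; within the scatter) and a 1.4-fold lower number from compound 2 to compound 4 (0.14 log units; within the scatter) show that pyridin-3-yl can take the place of either dichlorophenyl group with no change that can be trusted, even though both chlorine atoms go and a ring nitrogen with a hydrogen-bond acceptor enters. The earlier compounds shown here showed only that the arrangement of the chlorines could vary, whereas these steps show that, on a saturated chain carbon bound to an amine nitrogen in a ring, the chlorines can be absent altogether, while the one large difference remains the step of an 11-fold lower number from compound 1 to compound 4 (1.03 log units; beyond the scatter) that comes with (pyridin-3-yl)methyl in place of benzoyl. No measurement shown here explains why these aromatic rings are interchangeable.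

The compounds shown leave open whether an aromatic ring is needed in this place at all, which a cyclohexyl group or a plain methyl group would test, and whether the site of the ring nitrogen counts, which pyridin-4-yl would test. They also leave open how much of the gap to compound 1 belongs to the carbonyl link, a question that an unsubstituted phenyl on the same chain carbon would address.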